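Three aryl-piperazine analogues at the assay ceiling

The source may hold more compounds than are shown below. What is called first, only, known or untested is meant among the compounds shown, and "the series" means these compounds.

Measured in a functional assay on HeLa cells (Homo sapiens) for antiproliferative activity, read by MTT assay, with a stated time of 48 h; on this read-out lower numbers stand for stronger inhibition and higher numbers for weaker inhibition:

compound 1 `S=c1oc(-c2ccc3c(c2)OCCO3)nn1CN1CCN(c2ccccc2)CC1` — > 50000 nM
compound 2 `Fc1ccc(N2CCN(Cn3nc(-c4ccc5c(c4)OCCO5)oc3=S)CC2)cc1` — > 50000 nM
compound 3 `COc1ccc(N2CCN(Cn3nc(-c4ccc5c(c4)OCCO5)oc3=S)CC2)cc1` — > 50000 nM

Each of these three values is a limit of this assay and not a number. For compound 3 the result > 50000 nM is such a limit, so compound 3 stands nowhere on a scale of numbers: it only shares the ceiling with the two companions, as the limit of > 50000 nM in this assay, at which 3 of the 3 values shown sit, records. The steps among the measured compounds are therefore all unreadable: a step that the two limits leave unreadable from compound 1 to compound 2, a step that the two limits leave unreadable from compound 1 to compound 3 and a step that the two limits leave unreadable from compound 2 to compound 3, none of which reveals a size.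

Compound 4 `S=c1oc(-c2ccc3c(c2)OCCO3)nn1CN1CCN(c2ccccc2Cl)CC1` differs from compound 3 by 2-chlorophenyl in place of 4-methoxyphenyl on an amine nitrogen in a ring. For the measured compounds named here, the only steps that bear on it are the substituent exchanges on the same ring, and all three lie between limits, so no size can be derived from them; what they show is that a hydrogen, a fluoro and a methoxy on that ring all leave the compound at the ceiling.

Compound 4 is therefore expected to stay near that ceiling, the estimated step being a number no higher from compound 3 to compound 4 (the limit leaves the size open). Compound 4 is estimated at 50000 nM, within 15000 nM to 200000 nM, most probably reported again only as a limit.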

Compound 4, half-maximal inhibitory concentration: 37400 nM
Compound 4: the middle estimate sits 1.3-fold (0.13 log units) above what was measured; low and high end bracket the measured number.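

In this assay, for the compounds shown here, compound 4 is the only one of the four compounds to return a number, so 2-chlorophenyl is the first group on this amine nitrogen in a ring to give a value that can be read. Compound 1, compound 2 and compound 3 remain limits of the assay, and the steps among them still cannot be read: the limit of > 50000 nM in this assay, at which 3 of the 4 values shown sit. The new result gives an at least 1.3-fold lower number from compound 3 to compound 4 (0.12 log units; that floor lies within the scatter), an at least 1.3-fold lower number from compound 2 to compound 4 (0.12 log units; that floor lies within the scatter) and an at least 1.3-fold lower number from compound 1 to compound 4 (0.12 log units; that floor lies within the scatter), and these are floors only, so they fix neither the true size of any step nor a change beyond the scatter.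

The compounds shown leave open whether the number follows from the chloro itself, as a bromo or a trifluoromethyl on the same aromatic ring could test, and how far the value would move with either group. They also leave open what a benzyl group or a longer chain on that amine nitrogen would give in this assay.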